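The compounds below may be only part of what the source reports. "The series", "measured", "known", "first", "only" and "open" are said of these compounds alone.

Compound 3, whose structure is `ClCc1ccccc1Cn1cnc2nc(Cl)nc(Cl)c21`, was tested in a functional assay on K562 cells (Homo sapiens) for cytotoxicity, read by sulforhodamine B assay, with a stated time of 48 h (on this read-out higher numbers stand for weaker inhibition of growth and lower numbers for stronger inhibition of growth), where compound 3 gives 690 nM. Compound 2, with the structure `ClCc1ccccc1Cn1cnc2ncnc(Cl)c21`, differs from it in one place: the change is hydrogen in place of chloro on an aromatic carbon, and in this assay compound 2 gives 5880 nM. The step recorded is an 8.5-fold higher number from compound 3 to compound 2 (0.93 log units; beyond the scatter), so taking the chloro away weakened growth inhibition here.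

Compound 1, with the structure `ClCc1ccc(Cn2cnc3nc(Cl)nc(Cl)c32)cc1`, carries the same atoms as compound 3 joined differently; the difference between the two cores is not broken down here. For compound 1 only a limit of this assay is known, namely > 100000 nM, which is the limit of > 100000 nM in this assay, at which 1 of the 3 values shown sits.

Compound 4, with the structure `ClCc1ccc(Cn2cnc3ncnc(Cl)c32)cc1`, has not been measured in this assay. It stands to compound 1 as compound 2 stands to compound 3: the change is hydrogen in place of chloro on an aromatic carbon, the same change, at the same kind of place, as that between compound 3 and compound 2. Because the earlier step was an 8.5-fold higher number from compound 3 to compound 2 (0.93 log units; beyond the scatter), the expectation is that compound 4 will likewise show a weaker growth inhibition than compound 1, the expected step being a step that the limit leaves unreadable from compound 1 to compound 4, though since compound 1 already sits at a limit of this assay, compound 4 is very likely to do so as well. The estimate for compound 4 in this assay is 300000 nM, with a range from 80000 nM to 2000000 nM.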

Compound 4, concentration for total growth inhibition: > 100000 nM
Compound 4: only a limit was reported (the forecaster's own chance of this, stated with the estimate: 90%); the middle value is on the limit's open side.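

In this assay compound 4 gives > 100000 nM, which is a limit of the assay. Compound 1 also sits at a limit, so no step can be read between compound 1 and compound 4: the limit of > 100000 nM in this assay, at which 2 of the 4 values shown sit.

The compounds shown leave open whether hydrogen in place of chloro on an aromatic carbon changes growth inhibition in the core of compound 1, as it did between compound 3 and compound 2.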